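The source may report more compounds than this note shows. Statements on the series, on what has been measured and on what is new or still open speak of the compounds shown alone.

Going by the values given here, compound 2 `COc1cccc(-c2ccc(-n3cc(-c4cccc(C(=O)O)c4)nn3)cc2)c1` gives 856 ug/mL in a physicochemical assay for solubility, measured as thermodynamic solubility (a lower number here means a less soluble compound, a higher number a more soluble compound), the highest of the two numbers measured so far; its nearest neighbour is compound 1 `COc1cc(OC)cc(-c2ccc(-n3cc(-c4cccc(C(=O)O)c4)nn3)cc2)c1`, which in this assay gives 18.7 ug/mL. Among the compounds with values here, the only measured step, a 46-fold higher number from compound 1 to compound 2 (1.66 log units; beyond the scatter), concerns a methoxy group and not the change at hand. Compound 3 `COc1ccc(F)c(-c2ccc(-n3cc(-c4cccc(C(=O)O)c4)nn3)cc2)c1` differs from compound 2 by fluoro in place of hydrogen on an aromatic carbon. Within the data shown here, no measured step bears on this change, so for compound 3 a step no larger than the scatter is expected, a 1.7-fold lower number from compound 2 to compound 3 (0.23 log units; within the scatter). Compound 3 is estimated at 500 ug/mL, within 200 ug/mL to 1200 ug/mL.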

Compound 3, solubility: 1170 ug/mL
Estimate against measurement, compound 3: 2.3-fold (0.37 log units) below; measured number inside the range.
By their numbers in this assay, from the lowest: compound 1; then compounds 2 and 3 (each within the scatter of the next).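

In this assay, fluoro in place of hydrogen at this position, ortho to a large group and para to a methoxy group, gives a 1.4-fold higher number from compound 2 to compound 3 (0.14 log units; within the scatter), so this change on the 3-methoxyphenyl leaves the read-out within the scatter. The 2-fluoro-5-methoxyphenyl in place of 3,5-dimethoxyphenyl gives a 63-fold higher number from compound 1 to compound 3 (1.80 log units; beyond the scatter), which places compound 3 with compound 2, well clear of compound 1. Nothing available accounts for either step. On these data alone, whether a larger group at this position, such as an amine or a longer chain, would also leave the read-out unmoved stays open. So does whether fluoro would behave alike elsewhere on this ring.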